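A few compounds are considered here, and "the series" means these few. Any claim that something is new, unique, unknown or untested is made for them only; others in the source may bear on it.

Three members of the series have a result in an assay on HEK293 cells for positive allosteric modulation of metabotropic glutamate receptor 2 (Rattus norvegicus), read by thallium flux; a higher number here means a larger maximal response, a lower number a smaller maximal response. Compound 1 `COc1ccc(C(=O)O)cc1-c1cccc(COc2ccc3c(c2)CN(C2CCCC2)C3=O)c1` gives 79.2%, the second highest of the three numbers. Compound 3 `O=C(O)c1cc(-c2cccc(COc3ccc4c(=O)n(C5CCCC5)sc4c3)c2)ccc1F` gives 83.4%, and the gap between compound 3 and compound 1 lies within the scatter. Compound 2 `CC(C)CCn1sc2cc(OCc3cccc(-c4ccc(Cl)c(C(=O)O)c4)c3)ccc2c1=O` gives 67.3%, and the gap between compound 2 and compound 1 lies beyond the scatter. The next compound, compound 4 `Cc1ccc(C(=O)O)cc1-c1cccc(COc2ccc3c(c2)CN(C2CCCC2)C3=O)c1`, is not yet measured. It differs from compound 1 in one place: methyl in place of methoxy on an aromatic carbon. Among the compounds with values here, no pair of measured compounds differs in only one place, so no measured step guides the size of the change to be expected. The three results so far span a narrow band, and the exchange is confined to a single position ortho to a large group and para to a carboxy group. For compound 4 the expectation is therefore a step within the scatter of this assay, with no clear direction, a number 3.2 percentage points lower from compound 1 to compound 4 (within the scatter). The estimated value for compound 4 is 76%, with a range from 62% to 90%.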

Compound 4, largest response reached (reported as percent of maximum), in percent of the reference or control that the assay uses: 80.8%
Beside the measured number, compound 4's estimate is 4.8 percentage points below it, and the stated range covers the measured number.
By their numbers in this assay, from the lowest: compound 2; then compounds 1, 4 and 3 (each within the scatter of the next).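

In this assay, within the data shown here, the exchange on the 5-carboxy-2-methoxyphenyl group gives a number 1.6 percentage points higher from compound 1 to compound 4 (within the scatter), and this is the only single-place step so far. At this position, ortho to a large group and para to a carboxy group, methyl can therefore stand in place of methoxy with one heavy atom and one hydrogen-bond acceptor fewer, and the step stays within the scatter. No measurement at hand accounts for this result.

The compounds shown leave open whether a chlorine atom, an amine or a longer chain such as ethoxy at this position would also stay within the scatter of compound 1. Also open, from the compounds shown here alone, is whether the same exchange of methoxy for methyl would read alike on the core of compound 3.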